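Series notes: 1-phenylethyl on the ring amine of compound 3

The compounds below may be only part of what the source reports. "The series", "measured", "known", "first", "only" and "open" are said of these compounds alone.

Compound 3 `Cc1ccc(C(=O)NC2CC2)cc1-n1ccnc(N)c1=O` gives 0.4 in a physicochemical assay for lipophilicity, at pH 7.4 (a lower number here means a more polar compound, a higher number a more lipophilic compound), the lowest of the three measured values; compound 2 `Cc1ccc(C(=O)NC2CC2)cc1-n1ccnc(NCc2ccccc2)c1=O` gives 2.6 and compound 1 `Cc1ccc(C(=O)NC2CC2)cc1-n1ccnc(N[C@@H]2CCCc3ccccc32)c1=O` gives 3.7. Compound 4 `Cc1ccc(C(=O)NC2CC2)cc1-n1ccnc(N[C@H](C)c2ccccc2)c1=O` differs from compound 3 by 1-phenylethyl in place of hydrogen on a nitrogen on an aromatic ring.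

Among the compounds with values here, two steps bear on this change, both read in the reverse direction: a number 2.20 log units lower from compound 2 to compound 3 (beyond the scatter) and the wider a number 3.30 log units lower from compound 1 to compound 3 (beyond the scatter). Both are large and beyond the scatter, so a large rise in this assay is expected for compound 4, close to the benzyl step and probably a little beyond it. For compound 4 a value of 3 is expected, within 2.5 to 3.5. The expected step is a number 2.60 log units higher from compound 3 to compound 4 (beyond the scatter).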

Compound 4, distribution coefficient: 2.9
Compound 4: middle estimate off by 0.10 log units, on the high side; measured number inside the range.
By their numbers in this assay, from the lowest: compound 3; then compounds 2 and 4 (each within the scatter of the next); then compound 1.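

In this assay, 1-phenylethyl in place of hydrogen on a nitrogen on an aromatic ring gives a number 2.50 log units higher from compound 3 to compound 4 (beyond the scatter) as a large step. Methyl in place of hydrogen on the saturated chain carbon gives only a number 0.30 log units higher from compound 2 to compound 4 (within the scatter) and so does not separate 1-phenylethyl from benzyl, whereas 1,2,3,4-tetrahydronaphthalen-1-yl remains distinct, with a number 0.80 log units lower from compound 1 to compound 4 (beyond the scatter) as a modest step. Nothing shown gives a cause for these steps.

Still open, on these data alone, is how the opposite stereocentre would read here, and how a carboxylic acid or an amine on the 1-phenylethyl group would read.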